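Ring changes on the sulfonyl sulfur and cell toxicity

A few compounds are considered here, and "the series" means these few. Any claim that something is new, unique, unknown or untested is made for them only; others in the source may bear on it.

Measured compounds:
Compound 1 `O=C(Nc1ccc(F)c(Cl)c1)c1ccc(F)c(S(=O)(=O)N2CCCCCCC2O)c1`: 7000 nM
Compound 2 `O=C(Nc1ccc(F)c(Cl)c1)c1ccc(F)c(S(=O)(=O)N2CCCCC(O)CC2)c1`: 24000 nM
Compound 3 `O=C(Nc1ccc(F)c(Cl)c1)c1ccc(F)c(S(=O)(=O)N2CCCCC(O)C2)c1`: 15000 nM

All three compounds share a core and differ only in the ring attached to the sulfonyl sulfur. In an ADME assay on HepG2 2.2.15 cells (Homo sapiens) for cytotoxicity, read by luminescence, with a stated time of 3 days (on this read-out lower numbers stand for higher toxicity in this test and higher numbers for lower toxicity in this test), compound 1 gives the lowest number of the three, so it is the most toxic here. Replacing its ring gives a 3.4-fold higher number from compound 1 to compound 2 (0.54 log units; beyond the scatter) and a 2.1-fold higher number from compound 1 to compound 3 (0.33 log units; beyond the scatter), both modest moves toward lower toxicity, while compound 2 and compound 3 lie within the scatter of each other (a 1.6-fold lower number from compound 2 to compound 3 (0.20 log units; within the scatter)).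

Compound 4 `O=C(Nc1ccc(F)c(Cl)c1)c1ccc(F)c(S(=O)(=O)N2CCSCC(O)C2)c1` is not yet measured. It differs from compound 1 by a group of 8 heavy atoms (5 carbon, 1 nitrogen, 1 oxygen, 1 sulfur; one seven-membered non-aromatic ring with 2 hetero atoms) in place of a group of 9 heavy atoms (7 carbon, 1 nitrogen, 1 oxygen; one eight-membered non-aromatic ring with 1 hetero atom), on a sulfonyl sulfur. The closest measured step is the move to a seven-membered ring in compound 3, which gave a 2.1-fold higher number from compound 1 to compound 3 (0.33 log units; beyond the scatter). A similar modest rise in the number is therefore expected for compound 4 in this assay, as a 1.9-fold higher number from compound 1 to compound 4 (0.27 log units; within the scatter). The estimate for compound 4 is 13000 nM, with a range from 6000 nM to 30000 nM.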

Compound 4, half-maximal cytotoxic concentration: 19000 nM
The estimate for compound 4 lay 1.5-fold (0.16 log units) below the measured number; low and high end bracket the measured number.
By their numbers in this assay, from the lowest: compound 1; then compounds 3, 4 and 2 (each within the scatter of the next).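

In this assay, the sulfur-containing seven-membered ring of compound 4 also stands clear of the eight-membered ring of compound 1 (a 2.7-fold higher number from compound 1 to compound 4 (0.43 log units; beyond the scatter)), so all three other rings now read beyond the scatter from compound 1. Swapping a ring carbon for sulfur shows no readable change at this position on the sulfonyl sulfur (a 1.3-fold higher number from compound 3 to compound 4 (0.10 log units; within the scatter)), and compound 4 also sits within the scatter of the other eight-membered ring (a 1.3-fold lower number from compound 2 to compound 4 (0.10 log units; within the scatter)). Nothing available explains why compound 1 stands apart.

From the compounds shown here alone, how a ring oxygen or a ring nitrogen in place of that sulfur would read in this test remains open. Every ring shown carries a hydroxyl, so what a methoxy or an amine in its place would do also stays open.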